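A few compounds are considered here, and "the series" means these few. Any claim that something is new, unique, unknown or untested is made for them only; others in the source may bear on it.

Three compounds share one core, a urea linking a methylquinoline to a substituted phenyl ring. Compound 1 `Cc1cc(NC(=O)Nc2ccccc2C(F)(F)F)c2ccccc2n1` carries a trifluoromethyl group; in an ADME assay on Raji cells (Homo sapiens) for cytotoxicity, with a stated time of 72 h (a higher number here means that more compound is needed for the effect, a lower number that less compound is needed), compound 1 gives only a limit, > 25000 nM. Compound 2 `Cc1cc(NC(=O)Nc2ccc(N)cc2)c2ccccc2n1` carries an amino group; in this assay compound 2 likewise reaches only a limit, > 25000 nM. Compound 3 `CC(=O)c1ccc(NC(=O)Nc2cc(C)nc3ccccc23)cc1` carries an acetyl group; in this assay compound 3 also stops at a limit, > 25000 nM. For the measured compounds named here, the one step between measured compounds that differ in a single place, a step that the two limits leave unreadable from compound 2 to compound 3, cannot be read because of the limit of > 25000 nM in this assay, at which 3 of the 3 values shown sit. Compound 3 therefore stands where every measured compound stands, at the limit of this assay.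

Compound 4 `Cc1cc(NC(=O)Nc2ccc(C(C)(C)C)cc2)c2ccccc2n1` differs from compound 3 as follows: tert-butyl in place of acetyl on an aromatic carbon. Going by the values given here, no measured step bears on this exchange, and none of the three values gives a number to build on. Since all three sit at the limit, the step that the limit leaves unreadable from compound 3 to compound 4 is expected to be none beyond the scatter. In this assay compound 4 is estimated at 30000 nM, with a range from 8000 nM to 120000 nM, and most probably a limit again.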

Compound 4, half-maximal effective concentration: > 25000 nM
Compound 4 was reported as a limit; the forecaster's own chance of this, stated with the estimate: 80%; the middle value is on the limit's open side.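

The steps from compound 2 and from compound 3 to compound 4 cannot be read because both values in each pair are limits: the limit of > 25000 nM in this assay, at which 4 of the 4 values shown sit. The compounds shown leave open whether any group at this place on the shared core would give a readable value in this assay.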